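This account rests on a few compounds, and the source may have more. Where it says the series, first, only, none or still open, it means among the compounds named here.

compound 1 `CC(O)c1nc([C@@H](O)[C@H](O)[C@H](O)CO)c[nH]1` gives 16.4 mL/min/kg
compound 2 `CN(C)C(=O)c1nc([C@@H](O)[C@H](O)[C@H](O)CO)c[nH]1` gives 11.3 mL/min/kg
compound 3 `Cc1nc(-c2nc([C@@H](O)[C@H](O)[C@H](O)CO)c[nH]2)cs1` gives 19.4 mL/min/kg

All three values come from an in vivo ADME assay on the whole organism (strain 129/SvEvBrd x C57BL/6) for pharmacokinetics, with Mus musculus as the target, at a dose of 1 mg/kg by the intravenous route (on this read-out lower numbers stand for slow clearance and higher numbers for fast clearance), and describe how quickly the body removes each compound from the blood. Compound 3, at 19.4 mL/min/kg in this set, cannot be separated from its two neighbours. The data show a 1.2-fold higher number from compound 1 to compound 3 (0.07 log units; within the scatter) and a 1.7-fold higher number from compound 2 to compound 3 (0.23 log units; within the scatter) as the two steps that reach it.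

The next compound is compound 4 `OC[C@@H](O)[C@@H](O)[C@H](O)c1c[nH]c(-c2cscn2)n1` and it differs from compound 3 by one small edit, hydrogen in place of methyl on an aromatic carbon in the thiazole group. In words, hydrogen takes the place of methyl on an aromatic carbon, which turns 2-methyl-1,3-thiazol-4-yl into 1,3-thiazol-4-yl.

For the measured compounds named here, no measured pair isolates this methyl, so the evidence is indirect. The closest guide is how little the read-out moved when whole groups were exchanged on the shared core. Besides the two steps above, the data give a 1.5-fold lower number from compound 1 to compound 2 (0.16 log units; within the scatter) as the third step. Removing a single methyl is a smaller edit than any of these, so no step beyond the scatter is expected. The expected change is a 1.1-fold lower number from compound 3 to compound 4 (0.06 log units; within the scatter) in this estimate. For compound 4 the estimated clearance is 17 mL/min/kg with an expected range from 9.5 mL/min/kg to 30 mL/min/kg when measured.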

Compound 4, clearance: 12.7 mL/min/kg
The estimate for compound 4 lay 1.3-fold (0.13 log units) above the measured number; low and high end bracket the measured number.
By their numbers in this assay, from the lowest: compounds 2, 4, 1 and 3 (each within the scatter of the next).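

For the compounds shown here, compound 3 and compound 4 form the first pair that isolates this methyl, and in this assay the edit gives a 1.5-fold lower number from compound 3 to compound 4 (0.18 log units; within the scatter) so the methyl on this aromatic carbon, next to the ring nitrogen and next to the ring sulfur, can go without a step beyond the scatter. The 1,3-thiazol-4-yl group also stands close to the two non-thiazole groups on the shared core, with a 1.1-fold higher number from compound 2 to compound 4 (0.05 log units; within the scatter) against dimethylcarbamoyl and a 1.3-fold lower number from compound 1 to compound 4 (0.11 log units; within the scatter) against 1-hydroxyethyl, so all four compounds still cannot be separated on clearance by any step shown here. No supporting measurement is available to explain why these changes leave the read-out within the scatter.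

From the compounds shown here alone, at this ring carbon only hydrogen and methyl can be compared, so it remains open whether a longer chain such as n-butyl, an amine or a carboxylic acid there would produce a step beyond the scatter. Going by these compounds, all four compounds also carry the same hydroxyl-bearing chain on the shared core, so how clearance responds to changing that chain, for example by replacing a hydroxyl with a methoxy group, remains unknown.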